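Dropping the Methyl from a Urea-Bearing Adenosine Ligand

The source may hold more compounds than are shown below. What is called first, only, known or untested is meant among the compounds shown, and "the series" means these compounds.

Compound 1 `CCCn1c(-c2ccco2)nc2c(N)ncnc21` gives 19 nM in an assay on CHO cells for displacement of a labelled ligand from adenosine receptor A1 (Homo sapiens); a higher number here means a weaker inhibitor, a lower number a stronger inhibitor. Compound 2 `Cc1ccc(NC(=O)Nc2ncnc3c2nc(-c2ccco2)n3C)cc1` gives 756 nM in this assay, the highest of the two numbers, and its gap to compound 1 lies well beyond the usual scatter of repeated measurements. Compound 3 `Cn1c(-c2ccco2)nc2c(NC(=O)Nc3ccccc3)ncnc21` differs from compound 2 only in hydrogen in place of methyl on an aromatic carbon. Going by the values given here, no measured pair shows this change, so its size cannot be read off from the data; the expectation is a step that stays within the scatter, a 1.3-fold lower number from compound 2 to compound 3 (0.10 log units; within the scatter), with no clear direction. Compound 3 is therefore estimated at 600 nM in this assay, within a range from 250 nM to 1500 nM.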

Compound 3, inhibition constant: 496 nM
Compound 3: middle estimate off by 1.2-fold (0.08 log units), on the high side, and the stated range covers the measured number.
By their numbers in this assay, from the lowest: compound 1; then compounds 3 and 2 (each within the scatter of the next).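

Going from 4-methylphenyl to phenyl gives a 1.5-fold lower number from compound 2 to compound 3 (0.18 log units; within the scatter) in this assay, so this change on the aromatic carbon leaves no measurable mark on the number. Going by these compounds alone, this is the first direct reading of this change, and it shows that the methyl is not needed to keep the binding seen with compound 2. Nothing available here explains this result.

As far as these compounds go, whether a chlorine atom or a methoxy group at this place would also leave the number unmoved remains open. So does whether a longer chain in place of the methyl would do the same.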